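The source may report more compounds than this note shows. Statements on the series, on what has been measured and on what is new or still open speak of the compounds shown alone.

Going by the values given here, compound 1, `C=CCOc1c(C)c(C)c2c(c1C)CCC(C)(COc1ccc(/C=C3\SC(=O)NC3=O)cc1)O2`, is the stronger of the two compounds measured so far. In a functional assay on MCF7 cells (Homo sapiens), tested at 5 uM (a lower number here means a stronger effect, a higher number a weaker effect of the compound at the concentration tested), compound 1 gives 42%. Its companion compound 2, `C=CCOc1c(C)c(C)c2c(c1C)CCC(C)(COc1cccc(/C=C3\SC(=O)NC3=O)c1)O2`, carries the same groups but attached at a different point on the ring; in this assay compound 2 gives 92%, a weaker effect that lies beyond the scatter. Compound 3, `C=CCOc1c(C)c(C)c2c(c1C)CCC(C)(COc1ccc(/C=C3\SC(=O)NC3=O)cc1OCC)O2`, keeps the arrangement of compound 1 and adds one group: ethoxy in place of hydrogen on an aromatic carbon. Among the compounds with values here, no measured pair shows this kind of change, so its effect is unknown. The two values in hand only say that moving groups on this ring matters. The step from compound 1 to compound 3 is expected to be small, likely somewhat weakening: a number 10 percentage points higher from compound 1 to compound 3 (within the scatter). Compound 3 is estimated to give 52%, with a range from 28% to 80%.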

Compound 3, a percentage reported as activity, at one concentration (the size of the read-out at that concentration, not a potency): 87%
Compound 3: middle estimate off by 35 percentage points, on the low side; the measured number lies above the stated range.
By their numbers in this assay, from the lowest: compound 1; then compounds 3 and 2 (each within the scatter of the next).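

Ethoxy in place of hydrogen on this aromatic carbon, ortho to a large group, gives a number 45 percentage points higher from compound 1 to compound 3 (beyond the scatter) in this assay and so removes much of the effect seen with compound 1. This shows that a single added group at this position can matter greatly, whereas the earlier pair showed only that the place of attachment on the ring matters. Nothing measured here explains the loss.

As far as these compounds go, it remains open whether the loss is specific to ethoxy or extends to other groups on the same carbon, such as methoxy, a fluorine atom, an amine or a longer chain such as butoxy. Also open, from the compounds shown here alone, is whether ethoxy would have the same effect on another carbon of this ring.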